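Phenyl to 4-fluorophenyl on compound 3

The compounds below may be only part of what the source reports. "The series", "measured", "known", "first", "only" and "open" are said of these compounds alone.

Measured in an ADME assay on the whole organism (Rattus norvegicus, strain Sprague-Dawley) for pharmacokinetics; a higher number here means that more of the compound sits outside the plasma, a lower number that more of the compound stays in the plasma:
- compound 1 `CC1(C)C[C@H](c2c[nH]c3c(C(N)=O)cc(-c4ccc(F)cc4)cc23)CCS1(=O)=O` gives 4.7 L/kg
- compound 2 `NC(=O)c1cc(-c2ccccc2)cc2c(C3CCN(S(=O)(=O)CCCN4CCCC4)CC3)c[nH]c12` gives 1 L/kg
- compound 3 `NC(=O)c1cc(-c2ccccc2)cc2c(C3CCS(=O)(=O)CC3)c[nH]c12` gives 2.8 L/kg

Compound 3 (2.8 L/kg) lies within the scatter of compound 1 (4.7 L/kg). Compound 2 (1 L/kg) stands apart: the gap between it and compound 3 exceeds the scatter, and compound 3 has the higher number. The next compound to read in this assay is compound 4 `NC(=O)c1cc(-c2ccc(F)cc2)cc2c(C3CCS(=O)(=O)CC3)c[nH]c12`, which carries fluoro in place of hydrogen on an aromatic carbon, para to a large group (fluoro in place of hydrogen on an aromatic carbon). The same difference reads phenyl to 4-fluorophenyl.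

Within the data shown here, no pair of measured compounds shows this change alone, so the data give no direct size for it. The value of compound 3 (2.8 L/kg) serves as the anchor. Compound 1 also carries the 4-fluorophenyl group, and its value (4.7 L/kg) lies within the scatter of that anchor. The expected change is therefore none beyond the scatter, with an estimated 1.1-fold higher number from compound 3 to compound 4 (0.06 log units; within the scatter) as a small step at most. The value estimated for compound 4 is 3.2 L/kg (expected range 2 L/kg to 5 L/kg).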

Compound 4, volume of distribution at steady state: 3.7 L/kg
For compound 4 the middle estimate is 1.2-fold (0.06 log units) below the measured one; low and high end bracket the measured number.
By their numbers in this assay, from the lowest: compound 2; then compounds 3, 4 and 1 (each within the scatter of the next).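

In this assay this change now has a direct size of a 1.3-fold higher number from compound 3 to compound 4 (0.12 log units; within the scatter) for fluoro in place of hydrogen on an aromatic carbon, para to a large group, so at this position it moves the number no further than repeated measurements would. Among these compounds, compound 1 carries the same 4-fluorophenyl group but also differs from compound 3 in a second place, so the earlier compounds could not isolate this step. No measurement shown bears on the reason for so small a step.

Going by these compounds, whether chloro, methoxy, an amine or a carboxylic acid at the same place would also stay within the scatter remains open. Also open, on these data alone, is whether the change from phenyl to 4-fluorophenyl would read the same on compound 2, with its longer chain ending in a pyrrolidine.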